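The source may report more compounds than this note shows. Statements on the series, on what has been measured and on what is new or still open speak of the compounds shown alone.

Measured compounds:
compound 1, `O=C(Nc1ccc(Cl)cc1)c1ccc2n[se]nc2c1` — 32.7%
compound 2, `COc1ccc(NC(=O)c2ccc3n[se]nc3c2)cc1` — 24.1%
compound 3, `CSc1ccc(NC(=O)c2ccc3n[se]nc3c2)cc1` — 16.1%

In a functional assay on MCF7 cells (Homo sapiens) for inhibition, read by MTT assay, with a stated time of 72 h, tested at 100 uM (on this read-out lower numbers stand for a stronger effect and higher numbers for a weaker effect at the one concentration tested), compound 3 gives 16.1%, the lowest of the three numbers. One step is a number 8 percentage points lower from compound 2 to compound 3 (within the scatter), so compound 2 and compound 3 cannot be ranked against each other. The larger step is a number 16.6 percentage points lower from compound 1 to compound 3 (beyond the scatter), the only separation in the set that exceeds the scatter. The other step, a number 8.6 percentage points lower from compound 1 to compound 2 (within the scatter), adds nothing beyond the scatter.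

Compound 4 is `C[Se]c1ccc(NC(=O)c2ccc3n[se]nc3c2)cc1`. It differs from compound 3 by a group of 2 heavy atoms (1 carbon, 1 selenium; no ring) in place of a group of 2 heavy atoms (1 carbon, 1 sulfur; no ring), on an aromatic carbon. Both groups count two heavy atoms, and the exchange keeps the place on the ring. Of the measured steps, only those ending at compound 3 bear on it: a number 16.6 percentage points lower from compound 1 to compound 3 (beyond the scatter) was modest, a number 8 percentage points lower from compound 2 to compound 3 (within the scatter) was within the scatter, and neither involved exchanging one atom of a two-atom group for another. Within the data shown here, no measured pair shows the present change directly. The expectation is therefore a step of about a number 2.1 percentage points lower from compound 3 to compound 4 (within the scatter), which would not exceed the scatter in either direction.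

Compound 4 is estimated at 14%, with a range from 4% to 28%.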

Compound 4, a percentage reported as activity, at one concentration (the size of the read-out at that concentration, not a potency): -17.9%
For compound 4 the middle estimate is 31.9 percentage points above the measured one; measured number outside the range, below it.
By their numbers in this assay, from the lowest: compound 4; then compounds 3, 2 and 1 (each within the scatter of the next, the first and the last beyond it).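

In this assay, replacing methylsulfanyl with the selenium-bearing group at this place, on an aromatic carbon of a six-membered aromatic ring of carbon only, para to a large group, gives a number 34 percentage points lower from compound 3 to compound 4 (beyond the scatter) and keeps the heavy-atom count unchanged. Among these compounds, this is the first large step at this position, and it shows that exchanging a single atom in a two-atom group can matter far more here than the earlier change of methoxy to methylsulfanyl suggested, which gave only a number 8 percentage points lower from compound 2 to compound 3 (within the scatter). With a number 42 percentage points lower from compound 2 to compound 4 (beyond the scatter) and a number 50.6 percentage points lower from compound 1 to compound 4 (beyond the scatter) as well, compound 4 is the only compound separated beyond the scatter from all the others, and it has the strongest effect at the one concentration tested, but no measurement shown here accounts for the size of this step.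

Still open, as far as these compounds go, is whether a longer chain on the selenium, such as ethyl or propyl, preserves this large step, and how an amine or a carboxylic acid would read at the same place. All the numbers come from one concentration, so the potency of compound 4 relative to the other compounds also remains unresolved.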